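The compounds below may be only part of what the source reports. "The series", "measured", "known", "first", "only" and "open" are said of these compounds alone.

Measured so far:
compound 1, `CC(C)c1cccc(C(C)C)c1OC(=O)NS(=O)(=O)N(C(C)C)C(C)C`, gives 15000 nM in an assay on liver for inhibition of sterol O-acyltransferase 1 (Rattus norvegicus), using microsomes; a higher number here means a weaker inhibitor, a lower number a stronger inhibitor;
compound 2, `CCCCCCNS(=O)(=O)NC(=O)Oc1c(C(C)C)cccc1C(C)C`, gives 21000 nM in this assay;
compound 3, `Cc1cc(C(C)(C)C)c(OC(=O)NS(=O)(=O)N(C(C)C)C(C)C)c(C(C)(C)C)c1`, gives 3200 nM in this assay.

Compound 1 and compound 2 differ in one place only: hexylamino in place of diisopropylamino on a sulfonyl sulfur. That change made a 1.4-fold higher number from compound 1 to compound 2 (0.15 log units; within the scatter). Compound 4, `CCCCCCNS(=O)(=O)NC(=O)Oc1c(C(C)(C)C)cc(C)cc1C(C)(C)C`, is not yet measured; it stands to compound 3 exactly as compound 2 stands to compound 1, the difference being (hexylamino in place of diisopropylamino on a sulfonyl sulfur). In both pairs the place is a sulfonyl sulfur whose other neighbour is an amide-type nitrogen, so this is the same change made a second time. How the core of compound 3 differs from the core of compound 1 is not broken down here; compound 3 gives the lowest of the three numbers, clearly apart from the other two. Because the earlier step of a 1.4-fold higher number from compound 1 to compound 2 (0.15 log units; within the scatter) stayed within the scatter, the step from compound 3 to compound 4 is expected to be small as well, a 1.4-fold higher number from compound 3 to compound 4 (0.15 log units; within the scatter). Compound 4 is therefore estimated at 4500 nM, with a likely range from 2000 nM to 12000 nM.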

Compound 4, half-maximal inhibitory concentration: 19400 nM
Estimate against measurement, compound 4: 4.3-fold (0.63 log units) below, and the stated range ends below it.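

In this assay, putting hexylamino in place of diisopropylamino on the sulfonyl sulfur gave a 6.1-fold higher number from compound 3 to compound 4 (0.78 log units; beyond the scatter), so this change matters clearly on the core of compound 3. Its size did not carry over from the core of compound 1, and the two steps are truly different: the same change on two cores in this assay, a 1.4-fold higher number (0.15 log units; within the scatter) from compound 1 to compound 2 and a 6.1-fold higher number (0.78 log units; beyond the scatter) from compound 3 to compound 4, 4.3-fold (0.64 log units) apart, beyond the scatter of two such steps. A small step on one core is therefore no safe guide to the same change on another core in this series, but two pairs cannot show why the cores respond differently or predict the step on a third core.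

The compounds shown leave open how a shorter chain such as butylamino, or a ring amine such as piperidine, would behave at the same sulfonyl sulfur on either core. They also leave open which part of the difference between the two cores sets the size of the step.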